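The source may hold more compounds than are shown below. What is called first, only, known or untested is meant among the compounds shown, and "the series" means these compounds.

In an ADME assay on HEL cells (Homo sapiens) for cytotoxicity, with a stated time of 3 days (a higher number here means that more compound is tolerated, a lower number that less compound is tolerated), three compounds built on one shared core have been measured so far. Compound 1 `CCC1(Cc2ccccc2)OS(=O)(=O)CC1=O` gives 200000 nM in this assay. Compound 2 `CCC1(Cc2ccccc2)OS(=O)(=O)C=C1NCc1ccccc1`, which carries a benzylamino group on the core in place of the ketone, gives 92000 nM in this assay. Compound 3 `CCC1(Cc2ccccc2)OS(=O)(=O)C=C1OCc1ccc([N+](=O)[O-])cc1` did not return a number in this assay but only a limit, < 200000 nM, so its true value is known only as lying on one side of that threshold: the limit of < 200000 nM in this assay, at which 1 of the 3 values shown sits. Compound 3 therefore stands somewhere in the range where compounds 1 and 2 also sit, and no sharper placement is possible from the data at hand.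

The step now followed leads to compound 4 `CCC1(Cc2ccccc2)OS(=O)(=O)C=C1OCc1ccccc1`, which differs from compound 3 in one place: hydrogen in place of nitro on an aromatic carbon. Among the compounds with values here, no measured pair among the three known compounds shows the effect of such a change, so the expectation rests on the general picture, in which all three values are close together. The step from compound 3 to compound 4 is expected to be a step that the limit leaves unreadable from compound 3 to compound 4, that is, nothing that would stand out beyond the usual scatter. Compound 4 is accordingly estimated at 150000 nM, with a likely range from 60000 nM to 200000 nM, and a fair chance that this assay again reports only a limit.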

Compound 4, half-maximal cytotoxic concentration: 200000 nM
Compound 4: the middle estimate sits 1.3-fold (0.12 log units) below what was measured; the range from low to high includes it.
By their numbers in this assay, from the lowest: compound 2; then compounds 1 and 4 (each within the scatter of the next).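

In this assay, the new result gives a readable step on the shared core: with benzyloxy in place of benzylamino on a double-bonded ring carbon, there is a 2.2-fold higher number from compound 2 to compound 4 (0.34 log units; beyond the scatter), a modest change that lies beyond the usual scatter. Compound 3 gives only a limit of the assay, < 200000 nM. With hydrogen in place of nitro on an aromatic carbon, there is a number no lower from compound 3 to compound 4 (the limit leaves the size open), but the size of the change from 4-nitrophenyl to phenyl cannot be read, because one end of that step is only a limit: the limit of < 200000 nM in this assay, at which 1 of the 4 values shown sits.

The compounds shown contain no measured pair that reveals how a group on the aromatic ring, such as an amine or a carboxylic acid, would shift the tolerated concentration. On these data alone, it also remains open whether a longer chain in place of the benzyl part would keep the number of compound 4, and whether the step from benzylamino to benzyloxy would be of similar size on a core carrying other groups.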